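A few compounds are considered here, and "the series" means these few. Any claim that something is new, unique, unknown or untested is made for them only; others in the source may bear on it.

Compound 3 `CCCCC[Se]c1nc(NCc2ccccc2)c2ccccc2n1` was tested in an ADME assay on BEAS-2B cells (Homo sapiens) for cytotoxicity, read by MTT assay, with a stated time of 72 h (on this read-out higher numbers stand for weaker inhibition of growth and lower numbers for stronger inhibition of growth), where compound 3 gives 44100 nM. Among the three compounds measured so far it holds the second highest number. Its nearest neighbour is compound 2 `CSc1nc(NCCCCCO)c2ccccc2n1`, which gives 39300 nM; the furthest is compound 1 `CCCCC[Se]c1nc(N)c2ccccc2n1`, which gives 52300 nM. Both gaps lie within the scatter of repeated measurements, so none of the three can be called weaker or stronger than another on these numbers. Among the compounds with values here, the only single-site step recorded so far, a 1.2-fold lower number from compound 1 to compound 3 (0.07 log units; within the scatter), puts benzyl in place of hydrogen on a nitrogen on an aromatic ring and leaves the number essentially where it was.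

The next compound, compound 4 `CSc1nc(NCc2ccccc2)c2ccccc2n1`, differs from compound 3 at one place: a group of 2 heavy atoms (1 carbon, 1 sulfur; no ring) in place of a group of 6 heavy atoms (5 carbon, 1 selenium; no ring), on an aromatic carbon. Within the data shown here, no measured pair isolates this exchange. Compound 2 already carries a methylsulfanyl group, but its amine side differs, so compound 2 with its value of 39300 nM serves only as one more number in the same narrow band. With every measured number sitting within the scatter of every other, the expected step is a 1.1-fold lower number from compound 3 to compound 4 (0.02 log units; within the scatter), meaning no movement beyond the scatter. Compound 4 is therefore estimated at 42000 nM, with a likely range from 20000 nM to 90000 nM.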

Compound 4, concentration for 50% growth inhibition: 38900 nM
Compound 4: middle estimate off by 1.1-fold (0.03 log units), on the high side, within the range that was stated.
By their numbers in this assay, from the lowest: compounds 4, 2, 3 and 1 (each within the scatter of the next).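

Within the data shown here, the exchange on the aromatic carbon between two ring nitrogen atoms gives a 1.1-fold lower number from compound 3 to compound 4 (0.05 log units; within the scatter) in this assay, the first reading at this position, so a group of 6 heavy atoms carrying selenium and the much smaller methylsulfanyl cannot be told apart here. The second new step, a 1.0-fold lower number from compound 2 to compound 4 (0.00 log units; within the scatter), puts phenyl in place of 4-hydroxybutyl on the saturated chain carbon bound to a nitrogen, and it too stays within the scatter, so this cell read-out separates neither the groups on this carbon nor these two side groups on the nitrogen. No supporting measurement is available to account for these results.

In this exchange the atom bound to the aromatic carbon and the length of the group differ together. From the compounds shown here alone, the effect of each alone stays unknown; a pentylsulfanyl or a methylselanyl group at this carbon would separate them. Also open, going by these compounds, is whether a quite different group there, such as an amine or a carboxylic acid, would move the number beyond the scatter.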